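Chain Length and a Methylpiperazine on an Antiproliferative Core

The compounds below may be only part of what the source reports. "The series", "measured", "known", "first", "only" and "open" are said of these compounds alone.

Compound 1 `CN1CCN(CCn2c(N)c(-c3nc4ccccc4[nH]3)c3nc(C#N)c(C#N)nc32)CC1`: 40500 nM
Compound 2 `CCCn1c(N)c(-c2nc3ccccc3[nH]2)c2nc(C#N)c(C#N)nc21`: 1970 nM
Compound 3 `CN1CCN(CCCn2c(N)c(-c3nc4ccccc4[nH]3)c3nc(C#N)c(C#N)nc32)CC1`: 5750 nM

In a functional assay on A549 cells (Homo sapiens) for antiproliferative activity, read by MTT assay, with a stated time of 48 h (a higher number here means a weaker inhibitor, a lower number a stronger inhibitor), compound 1 gives 40500 nM, compound 2 gives 1970 nM and compound 3 gives 5750 nM. The change methyl in place of 4-methylpiperazin-1-yl on a saturated chain carbon, two bonds along the chain from an aromatic nitrogen produced a 21-fold lower number from compound 1 to compound 2 (1.31 log units; beyond the scatter). Compound 4 `CCCCn1c(N)c(-c2nc3ccccc3[nH]2)c2nc(C#N)c(C#N)nc21` carries the same kind of change, (methyl in place of 4-methylpiperazin-1-yl on a saturated chain carbon, three bonds along the chain from an aromatic nitrogen), relative to compound 3. The two cores differ by (4-methylpiperazin-1-yl)methyl in place of 4-methylpiperazin-1-yl on a saturated chain carbon, two bonds along the chain from an aromatic nitrogen, so the place of the change is three bonds along the chain from an aromatic nitrogen rather than two bonds along the chain from an aromatic nitrogen. The earlier step of a 2.9-fold higher number from compound 2 to compound 3 (0.47 log units; beyond the scatter) was modest. On that basis the step expected for compound 4 is a 2.9-fold lower number from compound 3 to compound 4 (0.46 log units; beyond the scatter), smaller than the earlier step from compound 1. Compound 4 is estimated at 2000 nM, expected to lie between 700 nM and 6000 nM.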

Compound 4, half-maximal inhibitory concentration: > 50000 nM
Compound 4: a limit, no number (the forecaster's own chance of this, stated with the estimate: 3%); at least 25-fold (1.39 log units) between middle value and limit.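

Compound 4 stands at a limit of the assay, not a number: the limit of > 50000 nM in this assay, at which 1 of the 4 values shown sits.

In this assay, methyl in place of 4-methylpiperazin-1-yl gives a 21-fold lower number from compound 1 to compound 2 (1.31 log units; beyond the scatter) but an at least 8.6-fold higher number from compound 3 to compound 4 (0.93 log units; beyond the scatter) so the change does not carry from one core to the other, and its direction reverses: the same change on two cores in this assay, a 21-fold lower number (1.31 log units; beyond the scatter) from compound 1 to compound 2 and an at least 8.6-fold higher number (0.93 log units; beyond the scatter) from compound 3 to compound 4, at least 170-fold (2.25 log units) apart, beyond the scatter of two such steps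

For methyl in place of hydrogen the series shows an at least 25-fold higher number from compound 2 to compound 4 (1.40 log units; beyond the scatter) and for ethyl in place of 4-methylpiperazin-1-yl it shows an at least 1.2-fold higher number from compound 1 to compound 4 (0.09 log units; that floor lies within the scatter) and no more. It does not show the true size of any step that ends at compound 4.

The compounds shown leave open whether this reversal would hold with a longer chain such as pentyl. They also leave open whether another amine, such as morpholin-4-yl, would behave like 4-methylpiperazin-1-yl on these chains.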